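This account rests on a few compounds, and the source may have more. Where it says the series, first, only, none or still open, it means among the compounds named here.

Compound 1 `Cc1ccc(Cn2cc(CSC(=S)N3CCN(C(=O)OC(C)(C)C)CC3)nn2)cc1` was tested in a functional assay on PC-3 cells (Homo sapiens) for inhibition, read by MTT assay, with a stated time of 72 h (on this read-out lower numbers stand for stronger inhibition and higher numbers for weaker inhibition), and in that test compound 1 gives 17300 nM. Compound 2 `CC(C)(C)OC(=O)N1CCN(C(=S)SCc2cn(Cc3ccc(Cl)cc3)nn2)CC1` differs from compound 1 only by methyl in place of chloro on an aromatic carbon. In this assay compound 2 reaches only a limit of the assay, > 128000 nM, and not a number. Read across this pair, the step of an at least 7.3-fold lower number from compound 2 to compound 1 (0.86 log units; beyond the scatter) is the one measured change of this kind. Compound 3 `S=C(SCc1cn(Cc2ccc(Cl)cc2)nn1)N1CCNCC1` shares the side group of compound 2 and differs from it by hydrogen in place of tert-butoxycarbonyl on an amine nitrogen in a ring; this is how the core of compound 3 differs from the core of compound 2. In this assay compound 3 likewise gives only a limit, > 128000 nM. The step that the two limits leave unreadable from compound 2 to compound 3 cannot be sized because of the limit of > 128000 nM in this assay, at which 2 of the 3 values shown sit.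

Compound 4 `Cc1ccc(Cn2cc(CSC(=S)N3CCNCC3)nn2)cc1` has not yet been measured in this assay. It differs from compound 3 by methyl in place of chloro on an aromatic carbon, which is the same change that separates compound 2 from compound 1, made on the other core. Among the compounds with values here, the expected step from compound 3 to compound 4 is estimated as an at least 3.6-fold lower number from compound 3 to compound 4 (0.56 log units; beyond the scatter), resting on the measured step of an at least 7.3-fold lower number from compound 2 to compound 1 (0.86 log units; beyond the scatter) and on the single value that compound 1 gives, 17300 nM. On that basis compound 4 is expected to give about 35000 nM in this assay, with the estimate spanning from 10000 nM to 128000 nM, and with a real chance that the assay again returns only a limit.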

Compound 4, half-maximal inhibitory concentration: 19800 nM
Beside the measured number, compound 4's estimate is 1.8-fold (0.25 log units) above it; low and high end bracket the measured number.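

In this assay the change from 4-chlorophenyl to 4-methylphenyl on the second core gives an at least 6.4-fold lower number from compound 3 to compound 4 (0.81 log units; beyond the scatter), so the drop seen on the first core appears again, and on both cores the step lies beyond the scatter: the same change on two cores in this assay, an at least 7.3-fold lower number (0.86 log units; beyond the scatter) from compound 2 to compound 1 and an at least 6.4-fold lower number (0.81 log units; beyond the scatter) from compound 3 to compound 4; the limit leaves it open whether they differ. This does not show that the change carries over with the same size, as compound 2 and compound 3 each give a limit and not a number, so neither step has a true size and the steps between those two compounds cannot be read: the limit of > 128000 nM in this assay, at which 2 of the 4 values shown sit. With the 4-methylphenyl group in place, hydrogen in place of tert-butoxycarbonyl on the ring nitrogen gives a 1.1-fold higher number from compound 1 to compound 4 (0.06 log units; within the scatter), and the matching step with the 4-chlorophenyl group stays unreadable, so the two places cannot be said to act independently of each other.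

The compounds shown hold only chloro and methyl at this position of the ring, and it stays open whether a fluoro, a methoxy or a plain hydrogen there would follow methyl or chloro. Going by these compounds, it also stays open how an acetyl or a benzyl group on the ring nitrogen would compare with tert-butoxycarbonyl and with hydrogen.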